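The compounds below may be only part of what the source reports. "The series", "measured", "known", "first", "only" and "open" are said of these compounds alone.

Values so far in a functional assay on U-87MG ATCC cells for inhibition, with U-87 MG (Homo sapiens) as the target, read by MTT assay, with a stated time of 72 h; on this read-out higher numbers stand for weaker inhibition and lower numbers for stronger inhibition

Compound 1 `COc1ccccc1-c1csc2cnc(Nc3ccc(NC(=O)C4CCNCC4)cc3)nc12` gives 1060 nM
Compound 2 `COc1ccccc1-c1csc2cnc(Nc3ccc(C(=O)NC4CCNCC4)cc3C(F)(F)F)nc12` gives 2090 nM

Compound 2 at 2090 nM stands within the usual scatter of compound 1 at 1060 nM, so the two values cannot be ordered. Compound 3 `COc1ccccc1-c1csc2cnc(Nc3ccc(C(=O)NC4CCNCC4)cc3)nc12` has hydrogen in place of trifluoromethyl on an aromatic carbon, ortho to a large group and meta to a (piperidin-4-yl)carbamoyl group: hydrogen in place of trifluoromethyl on an aromatic carbon. For the measured compounds named here, no measured pair differs in one place only, so the size of this step is a judgement without direct precedent. A step within the scatter is expected in this assay, leaning slightly towards a lower number: a 1.4-fold lower number from compound 2 to compound 3 (0.14 log units; within the scatter). For compound 3 the estimated value is 1500 nM, with an expected range of 550 nM to 4000 nM.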

Compound 3, half-maximal inhibitory concentration: 650 nM
Compound 3: middle estimate off by 2.3-fold (0.36 log units), on the high side; low and high end bracket the measured number.
By their numbers in this assay, from the lowest: compounds 3, 1 and 2 (each within the scatter of the next, the first and the last beyond it).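

In this assay the first pair differing in one place gives a 3.2-fold lower number from compound 2 to compound 3 (0.51 log units; beyond the scatter) on loss of trifluoromethyl, so this position responds to the change by more than the scatter, with trifluoromethyl on the side of the higher number. The (piperidin-4-yl)carbamoyl group in place of ((piperidin-4-yl)carbonyl)amino gives a 1.6-fold lower number from compound 1 to compound 3 (0.21 log units; within the scatter) and leaves these two compounds without an order, so no preference between the two amide arrangements can be read. Nothing at hand accounts for the trifluoromethyl step.

Open, from the compounds shown here alone, is whether fluoro, chloro or methyl on the same aromatic carbon would stand with hydrogen or with trifluoromethyl. Also open, going by these compounds, is whether a step of this size would recur with ((piperidin-4-yl)carbonyl)amino in place of (piperidin-4-yl)carbamoyl, and what an open-chain amine would do in place of the piperidine.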